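Cyclopentyl to oxan-4-yl on the series core

The compounds below may be only part of what the source reports. "The series", "measured", "known", "first", "only" and "open" are said of these compounds alone.

Compound 1 `COc1ccc(Nc2cc3[nH]c(-c4cccc(C(F)(F)F)c4)nc3cn2)nc1`: < 5000 nM (a limit)
Compound 2 `Fc1ccc(-c2nc3cnc(Nc4ccc(C(F)(F)F)cn4)cc3[nH]2)cc1F`: 6000 nM
Compound 3 `FC(F)(F)c1ccc(Nc2cc3[nH]c(C4CCCC4)nc3cn2)nc1`: 132000 nM

In a physicochemical assay for solubility, using the shake flask method, measured as kinetic solubility, with a stated time of 20 h, at pH 2 (a higher number here means a more soluble compound, a lower number a less soluble compound), compound 3 holds the highest of the two numbers, at 132000 nM, while compound 2 gives 6000 nM. Compound 1 gives < 5000 nM, which is a limit of the assay and not a number.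

The next compound is compound 4 `FC(F)(F)c1ccc(Nc2cc3[nH]c(C4CCOCC4)nc3cn2)nc1`, which carries oxan-4-yl in place of cyclopentyl on an aromatic carbon, between two ring nitrogen atoms: oxan-4-yl in place of cyclopentyl on an aromatic carbon.

Among the measured compounds shown here, one measured step bears on this carbon, a 22-fold higher number from compound 2 to compound 3 (1.34 log units; beyond the scatter), with cyclopentyl in place of 3,4-difluorophenyl. That step is large, but it replaces an aromatic group with a non-aromatic ring. Compound 3 and compound 4 both have a non-aromatic ring here, so that step gives no firm guide to the present change. Only a small upward move in this assay is expected, and nothing beyond the scatter.

The expected change is a 1.2-fold higher number from compound 3 to compound 4 (0.08 log units; within the scatter). For compound 4 the estimated value is 160000 nM, with an expected range of 60000 nM to 400000 nM.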

Compound 4, solubility: 196000 nM
The estimate for compound 4 lay 1.2-fold (0.09 log units) below the measured number, within the range that was stated.
By their numbers in this assay, from the lowest: compound 2; then compounds 3 and 4 (each within the scatter of the next). At a limit, below all of these: compound 1.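

At this carbon, between two ring nitrogen atoms, this assay does not separate the two non-aromatic rings, with a 1.5-fold higher number from compound 3 to compound 4 (0.17 log units; within the scatter) as the step from cyclopentyl to oxan-4-yl. The ring oxygen and the change from a five-membered to a six-membered ring therefore leave the number within the scatter, and the large step away from 3,4-difluorophenyl now appears again as a 33-fold higher number from compound 2 to compound 4 (1.51 log units; beyond the scatter) and no longer rests on cyclopentyl alone. Two non-aromatic rings thus stand well clear of the one 3,4-difluorophenyl compound in this comparison, but nothing measured in these notes gives a cause for either step.

The compounds shown leave open whether a piperidin-4-yl ring, with an amine in place of the ring oxygen, or a carboxylic acid on the ring at this carbon would move the number beyond the scatter. They also leave open whether oxan-4-yl keeps this standing when methoxy replaces trifluoromethyl on the other ring of the series.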